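From hydroxymethyl to ethoxycarbonyl on the saturated ring

The compounds below may be only part of what the source reports. "The series", "measured", "known", "first", "only" and "open" are said of these compounds alone.

Measured in an assay (strain Wistar) for inhibition of Hormone-sensitive lipase (Rattus norvegicus), read by spectrophotometry; a lower number here means a stronger inhibitor, a higher number a weaker inhibitor:
compound 1, `Cc1c(C(C)C)c(=O)on1C(=O)N1CCCCC1`, 2 nM
compound 2, `Cc1c(C(C)C)c(=O)on1C(=O)N1CCCCCC1`, 62 nM
compound 3, `Cc1c(C(C)C)c(=O)on1C(=O)N1CCCC(CO)C1`, 180 nM

Compound 3 has the highest number of the three in this assay; compound 2 stands nearest to it and compound 1 furthest. Compound 4, `CCOC(=O)C1CCCN(C(=O)n2oc(=O)c(C(C)C)c2C)C1`, differs from compound 3 by ethoxycarbonyl in place of hydroxymethyl on a saturated ring carbon. Among the measured compounds shown here, one measured step bears on this position: a 90-fold higher number from compound 1 to compound 3 (1.95 log units; beyond the scatter), which shows that a substituent on that ring carbon is poorly tolerated. Whether a group with more heavy atoms and no hydrogen-bond donor fares better or worse there is not told by these data, so no step beyond the scatter is expected in this assay. Compound 4 is estimated at 150 nM, between 30 nM and 800 nM. That estimate means an expected step of a 1.2-fold lower number from compound 3 to compound 4 (0.08 log units; within the scatter).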

Compound 4, half-maximal inhibitory concentration: 28 nM
Estimate against measurement, compound 4: 5.4-fold (0.73 log units) above; the whole stated range lies above it.
By their numbers in this assay, from the lowest: compound 1; then compound 4; then compound 2; then compound 3.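

Ethoxycarbonyl in place of hydroxymethyl gives a 6.4-fold lower number from compound 3 to compound 4 (0.81 log units; beyond the scatter) in this assay and so shows that this saturated ring carbon does not penalise every substituent alike. Even so, ethoxycarbonyl does not match hydrogen at this position, leaving a 14-fold higher number from compound 1 to compound 4 (1.15 log units; beyond the scatter) as the remaining cost of the substituent. Nothing measured here explains why the two groups differ.

The compounds shown leave open whether the carbonyl, the ethyl chain or the loss of the hydroxyl group accounts for the change. A carboxylic acid, a methyl ester or a methoxymethyl group on the same ring carbon could help separate these.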